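A few compounds are considered here, and "the series" means these few. Any claim that something is new, unique, unknown or untested is made for them only; others in the source may bear on it.

Compound 1 `Cc1cccc(OS(=O)(=O)c2ccc(N3CCN(C)C3=O)cc2)c1` and compound 2 `COc1cccc(OS(=O)(=O)c2ccc(N3CCN(C)C3=O)cc2)c1` share one core and differ in a single group: methoxy in place of methyl on an aromatic carbon. In a functional assay on MCF7 cells (Homo sapiens) for antiproliferative activity, read by sulforhodamine B assay, with a stated time of 48 h (a lower number here means a stronger inhibitor, a higher number a weaker inhibitor), compound 1 gives 5100 nM, and compound 2 gives 3000 nM; the step of a 1.7-fold lower number from compound 1 to compound 2 (0.23 log units; within the scatter) is small enough to be taken as no real change. Compound 3 `CCCN1CCN(c2ccc(S(=O)(=O)Oc3cccc(C)c3)cc2)C1=O` keeps the methyl-bearing ring of compound 1 but sits on a different core, the difference being (ethyl in place of hydrogen on a saturated chain carbon bound to an amide-type nitrogen in a ring). In this assay compound 3 gives 86000 nM, and the step of a 17-fold higher number from compound 1 to compound 3 (1.23 log units; beyond the scatter) is a large one. Compound 4 `CCCN1CCN(c2ccc(S(=O)(=O)Oc3cccc(OC)c3)cc2)C1=O` has not yet been measured. It differs from compound 3 by methoxy in place of methyl on an aromatic carbon, the same change that turned compound 1 into compound 2, made at a place described in exactly the same words, so it is the same change rather than merely the same kind. The step of a 1.7-fold lower number from compound 3 to compound 4 (0.24 log units; within the scatter) is expected to be about as small as before, because the earlier step of a 1.7-fold lower number from compound 1 to compound 2 (0.23 log units; within the scatter) stayed within the scatter. Compound 4 is therefore expected to give about 50000 nM in this assay, with a likely range from 20000 nM to 130000 nM.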

Compound 4, half-maximal inhibitory concentration: 6300 nM
Estimate against measurement, compound 4: 7.9-fold (0.90 log units) above, and the stated range ends above it.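

In this assay, the swap of methyl for methoxy is a large step on the core of compound 3 (a 14-fold lower number from compound 3 to compound 4 (1.14 log units; beyond the scatter)), so the near-absence of change on the core of compound 1 did not carry over: the same change on two cores in this assay, a 1.7-fold lower number (0.23 log units; within the scatter) from compound 1 to compound 2 and a 14-fold lower number (1.14 log units; beyond the scatter) from compound 3 to compound 4, 8.0-fold (0.90 log units) apart, beyond the scatter of two such steps. Read the other way, adding ethyl in place of hydrogen costs much less once the methoxy is present (a 2.1-fold higher number from compound 2 to compound 4 (0.32 log units; beyond the scatter)), and this step also fails to match its partner: the same change on two cores in this assay, a 17-fold higher number (1.23 log units; beyond the scatter) from compound 1 to compound 3 and a 2.1-fold higher number (0.32 log units; beyond the scatter) from compound 2 to compound 4, 8.0-fold (0.90 log units) apart, beyond the scatter of two such steps. So across these four compounds, the effect of each change depends on the other, which means that a step measured on one core cannot simply be added on another; the data do not show why this happens, or whether it holds beyond these two cores.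

On these data alone, it remains open how the swap would behave with a shorter ethyl or a longer butyl chain in place of the chain in compound 3. As far as these compounds go, whether a hydroxy or chloro group in place of the methoxy would follow compound 4 is also open.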